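Working notes: fluoro step from compound 2 to compound 4

A few compounds are considered here, and "the series" means these few. Any claim that something is new, unique, unknown or untested is made for them only; others in the source may bear on it.

Measured in a functional assay on LS174T cells (Homo sapiens) for inhibition, with a stated time of 4 days, tested at 100 nM; on this read-out lower numbers stand for a weaker effect and higher numbers for a stronger effect at the one concentration tested:
- compound 1 `Cn1ncc2cc(C#Cc3c(F)cccc3F)ccc21` gives 0%
- compound 2 `Fc1cccc(F)c1C#Cc1cnc2ccccc2c1` gives 0%
- compound 3 `Fc1cccc(F)c1C#Cc1cnc2ccccc2c1Cl` gives 0%

Compound 2 stands level with compound 1 and compound 3 at the digits shown; its nearest neighbour is compound 1 and its furthest is compound 3, and neither gap exceeds the scatter of the read-out. Among the compounds with values here, the single measured step, no change at the digits printed from compound 2 to compound 3 (within the scatter), was flat within the scatter, so a substituent added to the ring system of compound 2 has so far left the read-out where it was.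

Compound 4 `Fc1ccc2cc(C#Cc3c(F)cccc3F)cnc2c1` differs from compound 2 by fluoro in place of hydrogen on an aromatic carbon. Within the data shown here, of the measured steps only the one from compound 2 to compound 3 bears on this change, and it showed nothing beyond the scatter. Compound 4 is accordingly expected to move by no change at the digits printed from compound 2 to compound 4 (within the scatter) in this assay, which is no step beyond the scatter. The estimate for compound 4 is 0%, with a range from -5% to 10%.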

Compound 4, a percentage reported as inhibition, at one concentration (the size of the read-out at that concentration, not a potency): 14.8%
Compound 4: the middle estimate sits 14.8 percentage points below what was measured, outside the stated range (above it).
By their numbers in this assay, from the lowest: compounds 1, 2 and 3 (each within the scatter of the next); then compound 4.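

In this assay, within the data shown here, fluoro in place of hydrogen on an aromatic carbon of the six-membered aromatic ring of carbon only gives the first step beyond the scatter: a number 14.8 percentage points higher from compound 2 to compound 4 (beyond the scatter). The core of compound 2 therefore does not respond flatly to every substitution, whereas chloro in place of hydrogen gave no change at the digits printed from compound 2 to compound 3 (within the scatter). Nothing available accounts for the step from hydrogen to fluoro at this position.

From the compounds shown here alone, whether the rise belongs to fluoro itself or to this carbon stays open; chloro, methoxy or an amine on the same carbon would separate the two, as would fluoro on the other carbons of that ring. The read-out comes from a single concentration, so it gives the size of the effect of compound 4 and not its potency.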